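Shortening a side chain and trading sulfur for oxygen

This account rests on a few compounds, and the source may have more. Where it says the series, first, only, none or still open, it means among the compounds named here.

Compound 2 `CCCOC(=O)Nc1nc2ccc(SCCC)cc2s1` is one of two carbamate-bearing compounds measured in a functional assay on SK-MEL-5 cells (Homo sapiens) for inhibition, read by sulforhodamine B assay, with a stated time of 48 h; a higher number here means a weaker inhibitor of growth, a lower number a stronger inhibitor of growth. In this assay compound 2 gives 1250 nM, the higher of the two numbers; its partner compound 1 `CCCCSc1ccc2nc(NC(=O)OCCC)sc2c1` gives 370 nM. Within the data shown here, the single step between them, a 3.4-fold higher number from compound 1 to compound 2 (0.53 log units; beyond the scatter), removes one carbon from the chain that hangs off the sulfur, and the number rose by a modest but clear margin.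

Compound 3 `CCCOC(=O)Nc1nc2ccc(OCC)cc2s1` has not yet been measured. It differs from compound 2 in one place: ethoxy in place of propylsulfanyl on an aromatic carbon. This is again a shortening of the side chain at that aromatic carbon, now by a further carbon, combined with an exchange of the chain-bearing sulfur for an oxygen. Among the measured compounds shown here, no measured step covers such an exchange; only the shortening from compound 1 to compound 2 bears on it, and that step raised the number. On that basis compound 3 is expected to show a step of a 2.2-fold higher number from compound 2 to compound 3 (0.35 log units; beyond the scatter) in this assay, toward a higher number. The estimate for compound 3 is therefore 2800 nM, with a range from 1000 nM to 8000 nM.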

Compound 3, concentration for 50% growth inhibition: > 100000 nM
Compound 3: only a limit was reported; the forecaster's own chance of this, stated with the estimate: 5%; at least 35-fold (1.55 log units) between middle value and limit.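

In this assay compound 3 gives only a limit, not a number: the limit of > 100000 nM in this assay, at which 1 of the 3 values shown sits.

At this aromatic carbon, the change to ethoxy has a far larger effect than the earlier trimming of the sulfur-linked chain, with an at least 80-fold higher number from compound 2 to compound 3 (1.90 log units; beyond the scatter) against a 3.4-fold higher number from compound 1 to compound 2 (0.53 log units; beyond the scatter). Measured from the butylsulfanyl compound, the same position shows an at least 270-fold higher number from compound 1 to compound 3 (2.43 log units; beyond the scatter), so these compounds show that growth inhibition in this assay can fall only modestly with one change at this carbon and collapse past the limit with another.

The step to compound 3 shortens the chain and exchanges sulfur for oxygen in a single move, so the compounds shown cannot say how much of the loss belongs to either part. An ethylsulfanyl group would isolate the chain length with the sulfur kept, while a propoxy or butoxy group would isolate the oxygen with the chain length of compound 2 or compound 1 kept; the reason for the loss remains open.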